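Pentafluorophenyl Analogue in the Lipophilicity Series

The source may hold more compounds than are shown below. What is called first, only, known or untested is meant among the compounds shown, and "the series" means these compounds.

Compound 1 `Cc1cccc(C2=NO[C@]3(C2)C(=O)O[C@@H]2[C@H]3CC[C@H](C)[C@]3(O)C=CC(=O)[C@@]23C)c1` gives 1.86 in a physicochemical assay for lipophilicity; a lower number here means a more polar compound, a higher number a more lipophilic compound. Going by the values given here, compound 2 `C[C@H]1CC[C@@H]2[C@@H](OC(=O)[C@]23CC(c2ccc(C#N)cc2)=NO3)[C@]2(C)C(=O)C=C[C@@]12O` gives 1.17 in this assay, the single one-point step in hand being a number 0.69 log units lower from compound 1 to compound 2 (beyond the scatter). Compound 3 `C[C@H]1CC[C@@H]2[C@@H](OC(=O)[C@]23CC(c2ccc(F)cc2)N(c2ccccc2)O3)[C@]2(C)C(=O)C=C[C@@]12O` gives 3.35 in this assay and stands highest of the three measured values, compound 1 lying nearest and compound 2 furthest, both beyond the scatter. Compound 4 `C[C@H]1CC[C@@H]2[C@@H](OC(=O)[C@]23CC(c2c(F)c(F)c(F)c(F)c2F)N(c2ccccc2)O3)[C@]2(C)C(=O)C=C[C@@]12O` carries 2,3,4,5,6-pentafluorophenyl in place of 4-fluorophenyl on a saturated ring carbon. Among the compounds with values here, no measured step bears directly on this change: a number 0.69 log units lower from compound 1 to compound 2 (beyond the scatter) concerns a group on a carbon with a double bond to nitrogen, not the swap of one fluorinated phenyl for another. Starting from compound 3 at 3.35, the step of a number 0.50 log units higher from compound 3 to compound 4 (beyond the scatter) is expected to be a modest rise in this assay. Compound 4 is estimated at 3.85, between 3.3 and 4.4.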

Compound 4, partition coefficient: 3.72
Estimate against measurement, compound 4: 0.13 log units above, and the stated range covers the measured number.
By their numbers in this assay, from the lowest: compound 2; then compound 1; then compound 3; then compound 4.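

In this assay, going by these compounds alone, 2,3,4,5,6-pentafluorophenyl in place of 4-fluorophenyl on the saturated ring carbon gives a number 0.37 log units higher from compound 3 to compound 4 (beyond the scatter), the only step read so far at this position. Within the data shown here, the earlier step concerned a carbon with a double bond to nitrogen, so this is the first sign that the number still responds to change here, even from the top of the measured range. Nothing at hand accounts for the size of this step.

Open, going by these compounds, is how an amine or a longer alkyl chain at this position would compare with either fluorinated phenyl. On these data alone, a single pair also sets no trend, and whether the same exchange gives a similar step in other compounds remains untested here.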